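A few compounds are considered here, and "the series" means these few. Any claim that something is new, unique, unknown or untested is made for them only; others in the source may bear on it.

Three compounds that share one core and differ only in the group on a carbonyl carbon were measured in a physicochemical assay for solubility, read by LC-MS, in phosphate buffer, with a stated time of 24 h, at pH 6.8; a lower number here means a less soluble compound, a higher number a more soluble compound. Compound 1 `C[C@H](NC(=O)c1cccc(F)c1)c1ccc(NC(=O)N2CC(c3cccnc3)C2)cc1`, with 3-fluorophenyl in that place, gives 11000 nM. Compound 2 `C[C@H](NC(=O)C1CCOCC1)c1ccc(NC(=O)N2CC(c3cccnc3)C2)cc1`, with oxan-4-yl, gives 380000 nM. Compound 3 `CCC(=O)N[C@@H](C)c1ccc(NC(=O)N2CC(c3cccnc3)C2)cc1`, with ethyl, gives 700000 nM. The step of a 1.8-fold higher number from compound 2 to compound 3 (0.27 log units; within the scatter) lies within the scatter, so these two compounds stand level. The steps of a 35-fold higher number from compound 1 to compound 2 (1.54 log units; beyond the scatter) and a 64-fold higher number from compound 1 to compound 3 (1.80 log units; beyond the scatter) are both large and lie beyond the scatter.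

Compound 4 `CCC(=O)N[C@@H](C)c1ccc(NC(=O)N2CC(c3cncc(N)c3)C2)cc1` keeps the ethyl group of compound 3 but differs at another place: amino in place of hydrogen on an aromatic carbon. In other words, pyridin-3-yl becomes 5-aminopyridin-3-yl. All three measured steps are changes on the carbonyl carbon, and none is a change on this aromatic ring, so they bear on it only indirectly and give no direct size for it. The expectation therefore starts from compound 3 at 700000 nM, and it is a small step towards a lower number, not clearly beyond the scatter, held with wide uncertainty. The estimated step is a 1.8-fold lower number from compound 3 to compound 4 (0.24 log units; within the scatter). For compound 4 the expected value in this assay is 400000 nM, within an estimated range of 120000 nM to 1000000 nM.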

Compound 4, solubility: 230000 nM
Compound 4: middle estimate off by 1.7-fold (0.24 log units), on the high side; low and high end bracket the measured number.
By their numbers in this assay, from the lowest: compound 1; then compounds 4, 2 and 3 (each within the scatter of the next, the first and the last beyond it).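

Going by these compounds alone, the step of a 3.0-fold lower number from compound 3 to compound 4 (0.48 log units; beyond the scatter) gives the first reading at this place in this assay: amino in place of hydrogen on an aromatic carbon, two atoms from the ring nitrogen, moves the number modestly but beyond the scatter, whereas every earlier step was a change on the carbonyl carbon. The shared core therefore responds at this ring as well as at the carbonyl carbon, though this single change moves the number much less than the step of a 64-fold higher number from compound 1 to compound 3 (1.80 log units; beyond the scatter). Nothing available here accounts for the lower number with amino in this place.

The compounds shown leave open whether a methoxy group, a fluorine atom or a dimethylamino group in the same place would move the number in the same direction and by a similar amount, or whether the effect is particular to amino. They also leave open whether the amino step would keep its size with oxan-4-yl or 3-fluorophenyl on the carbonyl carbon in place of ethyl.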